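A few compounds are considered here, and "the series" means these few. Any claim that something is new, unique, unknown or untested is made for them only; others in the source may bear on it.

Measured so far in a functional assay on HEK293 cells for agonist activity at Bombesin receptor subtype-3 (Homo sapiens), read by luminescence and calcium flux, with a stated time of 10 min; on this read-out lower numbers stand for an effect already at smaller amounts and higher numbers for an effect only at larger amounts of compound:
compound 1 `CCC(C)(C)Cc1c[nH]c(CCc2ccc(-n3ncnn3)cc2)n1` — 89 nM
compound 2 `CCC(C)(C)Cc1c[nH]c(CCc2ccc(-c3cccc(C#N)n3)cc2)n1` — 95 nM
compound 3 `CCC(C)(C)Cc1c[nH]c(CCc2ccc(-n3cncn3)cc2)n1` — 89 nM

Compound 3 stands level with compound 1 at the digits given, and the two together hold the lowest of the three numbers; compound 2 is the furthest, yet still within the scatter. The steps among the measured compounds are all small: a 1.1-fold higher number from compound 1 to compound 2 (0.03 log units; within the scatter), no change at the digits printed from compound 1 to compound 3 (within the scatter) and a 1.1-fold lower number from compound 2 to compound 3 (0.03 log units; within the scatter). Replacing one five-membered ring by another, or by a cyano-substituted pyridyl, has left this assay unchanged.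

Compound 4 `CCC(C)(C)Cc1c[nH]c(CCc2ccc(-c3cccnc3C(=O)O)cc2)n1` differs from compound 3 by 2-carboxypyridin-3-yl in place of 1H-1,2,4-triazol-1-yl on an aromatic carbon. The three measured steps bear on it only in that they show the group at this position to be exchangeable among several aromatic rings without effect beyond the scatter. On these data alone, none of them introduces a carboxy group or a hydrogen-bond donor, so the new group is untested. On the measured steps alone the expectation is for compound 4 a step of no more than modest size in this assay, given as a 1.7-fold higher number from compound 3 to compound 4 (0.23 log units; within the scatter), with a wider range than usual to allow for the untested group. Compound 4 is therefore estimated at 150 nM, between 50 nM and 450 nM.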

Compound 4, half-maximal effective concentration: 95 nM
Beside the measured number, compound 4's estimate is 1.6-fold (0.20 log units) above it; low and high end bracket the measured number.
By their numbers in this assay, from the lowest: compounds 1, 3, 2 and 4 (each within the scatter of the next).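

With 2-carboxypyridin-3-yl, this position on a six-membered aromatic ring of carbon only, para to a large group, now carries the only carboxy group and the only hydrogen-bond donor among the compounds shown, and its 9 heavy atoms replace the 5 of 1H-1,2,4-triazol-1-yl; in this assay this exchange stays within the scatter (a 1.1-fold higher number from compound 3 to compound 4 (0.03 log units; within the scatter)). The same holds against the other two groups, 6-cyanopyridin-2-yl (no change at the digits printed from compound 2 to compound 4 (within the scatter)) and 2H-tetrazol-2-yl (a 1.1-fold higher number from compound 1 to compound 4 (0.03 log units; within the scatter)). Among these four compounds, then, this assay does not separate a carboxy-bearing six-membered ring from rings without a carboxy group, and the exchangeable set at this position is wider than the three earlier compounds showed.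

On these data alone, whether a primary amine, a methyl ester of the acid, or an open butyl chain in place of the aromatic ring would also stay within the scatter remains open, as does the outcome of any such exchange on a changed core. Nothing available here accounts for this flat response at the position.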